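A Methyl Added to the Core: Expected Half-Life

The source may report more compounds than this note shows. Statements on the series, on what has been measured and on what is new or still open speak of the compounds shown alone.

Compound 1, `Cc1c([C@H](OC(C)(C)C)C(=O)O)c(N2CCC(C)(C)CC2)c(-c2ccc(OCCc3ccc(F)cc3)cc2)c2nc(CC(C)C)cn12`: > 2 h
Compound 2, `Cc1c([C@H](OC(C)(C)C)C(=O)O)c(N2CCC(C)(C)CC2)c(-c2ccc(OCCc3ccc(F)cc3)cc2)c2ncnn12`: > 2 h

Of the compounds shown here, two have so far been tested in an ADME assay on microsomes from liver (Homo sapiens) for metabolic stability; a higher number here means that the compound lasts longer, a lower number that the compound disappears faster. Compound 1 `Cc1c([C@H](OC(C)(C)C)C(=O)O)c(N2CCC(C)(C)CC2)c(-c2ccc(OCCc3ccc(F)cc3)cc2)c2nc(CC(C)C)cn12` gives a reading that is only a limit of the assay, > 2 h. Compound 2 `Cc1c([C@H](OC(C)(C)C)C(=O)O)c(N2CCC(C)(C)CC2)c(-c2ccc(OCCc3ccc(F)cc3)cc2)c2ncnn12` likewise gives a reading that is only a limit of the assay, > 2 h. Compound 2 therefore stands at the same point as the other compound shown, namely at the limit of > 2 h in this assay, at which 2 of the 2 values shown sit, and no actual number places it higher or lower than compound 1.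

Compound 3 `Cc1nc2c(-c3ccc(OCCc4ccc(F)cc4)cc3)c(N3CCC(C)(C)CC3)c([C@H](OC(C)(C)C)C(=O)O)c(C)n2n1` has not yet been tested. It differs from compound 2 in one place: methyl in place of hydrogen on an aromatic carbon. Among the compounds with values here, no pair of tested compounds differs in a single place, so no measured step sets a scale for what this kind of change does in this assay. On the evidence at hand, the step from compound 2 to compound 3 is expected to be small, within the usual scatter, and in no particular direction, a step that the limit leaves unreadable from compound 2 to compound 3. Compound 3 is accordingly estimated to give 2.5 h in this assay, in the range from 1.2 h to 5 h, and it is expected that the reading most likely again comes back only as a limit.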

Compound 3, half-life: > 2 h
Compound 3: a limit, no number; the forecaster's own chance of this, stated with the estimate: 75%; the middle value does not contradict the limit.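

In this assay compound 3 gives > 2 h, which is a limit of the assay and not a number. Compound 2 also sits at a limit, so no step can be read between compound 2 and compound 3: the limit of > 2 h in this assay, at which 3 of the 3 values shown sit.

The compounds shown leave open the actual half-life of each one, and whether methyl in place of hydrogen on an aromatic carbon changes it at all.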